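The compounds below may be only part of what the source reports. "The series", "measured", "known", "first", "only" and "open" are said of these compounds alone.

Working notes on one shared core, followed in an ADME assay on microsomes from liver (Homo sapiens) for metabolic stability; on this read-out higher numbers stand for fast clearance and lower numbers for slow clearance. Going by the values given here, compound 1 `O=C(Nc1ccnnc1)c1cc(N2CCCC2)ccc1OCc1ccccc1` gives 9.8 mL.min-1.g-1, the highest of the three numbers so far. Compound 2 `C[C@@H]1CN(c2ccc(OCc3ccccc3)c(C(=O)Nc3ccnnc3)c2)C[C@H](C)O1` gives 2.2 mL.min-1.g-1, and compound 3 `CN1CCN(c2ccc(OCc3ccccc3)c(C(=O)Nc3ccnnc3)c2)CC1` gives 1.6 mL.min-1.g-1.

The unmeasured compound 4 `O=C(Nc1ccnnc1)c1cc(N2CCNCC2)ccc1OCc1ccccc1` differs from compound 1 at one place: piperazin-1-yl in place of pyrrolidin-1-yl on an aromatic carbon. Piperazin-1-yl replaces pyrrolidin-1-yl on an aromatic carbon, meta to the (pyridazin-4-yl)carbamoyl group and para to the benzyloxy group.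

Two measured steps replace the same pyrrolidin-1-yl group. They are a 4.5-fold lower number from compound 1 to compound 2 (0.65 log units; beyond the scatter) with 2,6-dimethylmorpholin-4-yl and a 6.1-fold lower number from compound 1 to compound 3 (0.79 log units; beyond the scatter) with 4-methylpiperazin-1-yl. Both lie beyond the scatter and both run toward lower numbers. The remaining step, a 1.4-fold lower number from compound 2 to compound 3 (0.14 log units; within the scatter), lies within the scatter, so compound 2 and compound 3 are not separated in this assay.

Among the compounds with values here, compound 3 is the closest measured neighbour by name, but no measured compound carries piperazin-1-yl itself, so the transfer is uncertain. A modest step toward a lower number is expected, similar in size to a 6.1-fold lower number from compound 1 to compound 3 (0.79 log units; beyond the scatter). The expected change is a 4.9-fold lower number from compound 1 to compound 4 (0.69 log units; beyond the scatter). For compound 4 the estimated value is 2 mL.min-1.g-1, with an expected range from 0.9 mL.min-1.g-1 to 4.5 mL.min-1.g-1.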

Compound 4, intrinsic clearance in microsomes: 0.4 mL.min-1.g-1
Beside the measured number, compound 4's estimate is 5.0-fold (0.70 log units) above it; the whole stated range lies above it.
By their numbers in this assay, from the lowest: compound 4; then compounds 3 and 2 (each within the scatter of the next); then compound 1.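

At the aromatic carbon para to a benzyloxy group, piperazin-1-yl gives the lowest number of the four compounds in this assay, with a 25-fold lower number from compound 1 to compound 4 (1.39 log units; beyond the scatter) as the largest step yet seen at this place. The earlier compounds shown here left 2,6-dimethylmorpholin-4-yl and 4-methylpiperazin-1-yl unseparated, whereas piperazin-1-yl stands clear of the first, with a 5.5-fold lower number from compound 2 to compound 4 (0.74 log units; beyond the scatter) as the step, and clear of the second, where hydrogen in place of methyl on the ring amine nitrogen gives a 4.0-fold lower number from compound 3 to compound 4 (0.60 log units; beyond the scatter) as a further fall, so that small change on the ring nitrogen moves the number beyond the scatter. No supporting measurement is available to explain this fall.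

The compounds shown leave open whether a longer chain on that ring nitrogen, such as ethyl, or an acetyl group there would stay near compound 3 or move toward compound 4. From the compounds shown here alone, it also remains open whether an open-chain amine at this aromatic carbon would give a similarly low number in this assay or whether the low number is confined to the intact piperazin-1-yl ring.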